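Thienopyrimidine series: amide swap at the para position

A few compounds are considered here, and "the series" means these few. Any claim that something is new, unique, unknown or untested is made for them only; others in the source may bear on it.

Working notes on the series. Compound 1 `COc1ccccc1-c1csc2cnc(Nc3ccc(NC(=O)C4CCNCC4)cc3)nc12` carries a ((piperidin-4-yl)carbonyl)amino group on the aniline ring and gives 1050 nM in a functional assay on MDA-MB-231 cells (Homo sapiens) for inhibition, read by MTT assay, with a stated time of 72 h; on this read-out lower numbers stand for stronger inhibition and higher numbers for weaker inhibition. Compound 2 `COc1ccccc1-c1csc2cnc(Nc3ccc(C(=O)NC4CCNCC4)cc3C(F)(F)F)nc12` gives 2750 nM in this assay; compound 1 stands lowest of the two numbers, with compound 2 the nearest and beyond the scatter. Going by the values given here, no step between two measured compounds that differ in one place is available.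

Compound 3 `CNC(=O)c1ccc(Nc2ncc3scc(-c4ccccc4OC)c3n2)cc1` is not yet measured. It differs from compound 1 in a single place: methylcarbamoyl in place of ((piperidin-4-yl)carbonyl)amino on an aromatic carbon. The group that enters is far smaller than the group that leaves, with fewer hydrogen-bond donors and acceptors and no ring, and the carbonyl now sits directly on the aromatic carbon.

With no measured step of this kind in the series, the expectation rests on compound 1 alone. The step from compound 1 to compound 3 is expected to be a 2.4-fold higher number from compound 1 to compound 3 (0.38 log units; beyond the scatter), a moderate weakening beyond the scatter. Compound 3 is thus estimated at 2500 nM in this assay, with a range from 800 nM to 8000 nM.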

Compound 3, half-maximal inhibitory concentration: 2120 nM
Compound 3: the middle estimate sits 1.2-fold (0.07 log units) above what was measured; the range from low to high includes it.
By their numbers in this assay, from the lowest: compound 1; then compounds 3 and 2 (each within the scatter of the next).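

In this assay, going by these compounds alone, the swap of ((piperidin-4-yl)carbonyl)amino for methylcarbamoyl on this aromatic carbon gives the first measured step, a 2.0-fold higher number from compound 1 to compound 3 (0.31 log units; beyond the scatter), which is modest but beyond the scatter. The change removes the six-membered non-aromatic ring and leaves a group with fewer heavy atoms, and it places the carbonyl directly on the aromatic carbon, yet this removal and relocation together cost only a modest weakening, so the full ((piperidin-4-yl)carbonyl)amino group is not needed for inhibition to remain measurable on this read-out. No measurement at hand bears on why the step has this size.

The single step changes the size of the group and the placement of the carbonyl at once, so the compounds shown leave open how much of the weakening belongs to each. Also open, from the compounds shown here alone, is how a simple primary amine, a carboxylic acid or a longer chain such as an N-(2-aminoethyl)carbamoyl group would read on this same aromatic carbon of the shared core.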